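Trading a Substituted Phenyl for a Chloropyridine

The source may report more compounds than this note shows. Statements on the series, on what has been measured and on what is new or still open speak of the compounds shown alone.

Three compounds have been measured in an in vitro assay on HEK385-7 cells for displacement of a labelled ligand from prostaglandin D2 receptor 2 (Homo sapiens); a lower number here means a stronger inhibitor, a higher number a weaker inhibitor:

Compound 1 `O=C(O)Cc1sc(C(c2ccc(F)cc2)c2ccc(F)cc2)nc1-c1ccccc1`: 16 nM
Compound 2 `N#Cc1ccc(-c2nc(C(c3ccc(F)cc3)c3ccc(F)cc3)sc2CC(=O)O)cc1`: 150 nM
Compound 3 `CS(=O)(=O)Nc1cccc(-c2nc(C(c3ccc(F)cc3)c3ccc(F)cc3)sc2CC(=O)O)c1`: 40 nM

All three share the same core and differ only in the aromatic group attached to it. Compound 3 stands second highest of the three numbers: the nearest is compound 1, at a 2.5-fold higher number from compound 1 to compound 3 (0.40 log units; beyond the scatter), and the furthest is compound 2, at a 3.8-fold lower number from compound 2 to compound 3 (0.57 log units; beyond the scatter).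

Compound 4 `O=C(O)Cc1sc(C(c2ccc(F)cc2)c2ccc(F)cc2)nc1-c1ccnc(Cl)c1` is the next step from compound 3. The change is 2-chloropyridin-4-yl in place of 3-(methanesulfonamido)phenyl on an aromatic carbon. Both earlier steps that bear on this position start from the plain phenyl of compound 1, and each substituent weakened binding: the cyano gave a 9.4-fold higher number from compound 1 to compound 2 (0.97 log units; beyond the scatter), the methanesulfonamido gave a 2.5-fold higher number from compound 1 to compound 3 (0.40 log units; beyond the scatter). Neither step tells directly what a ring nitrogen and a chlorine will do, so the expectation is that compound 4 lands near compound 3, with a step of a 1.3-fold higher number from compound 3 to compound 4 (0.10 log units; within the scatter) that is not expected to exceed the scatter. Compound 4 is therefore estimated at 50 nM, in a range from 15 nM to 200 nM.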

Compound 4, half-maximal inhibitory concentration: 3.1 nM
Beside the measured number, compound 4's estimate is 16-fold (1.21 log units) above it, and the stated range ends above it.
By their numbers in this assay, from the lowest: compound 4; then compound 1; then compound 3; then compound 2.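

Until now, both substituted rings at this position on the shared core had given a higher number than the plain phenyl, but in this assay the 2-chloropyridin-4-yl group goes the other way (a 5.2-fold lower number from compound 1 to compound 4 (0.71 log units; beyond the scatter)). The gains over the two substituted phenyl rings are larger still (a 13-fold lower number from compound 3 to compound 4 (1.11 log units; beyond the scatter); a 48-fold lower number from compound 2 to compound 4 (1.68 log units; beyond the scatter)), which makes compound 4 the strongest of the four and shows that this position can give better binding than the plain phenyl, not only worse. Nothing measured here explains why this ring binds better, and the change brings in a ring nitrogen and a chlorine together.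

What the compounds shown leave open is how much of the gain belongs to the ring nitrogen and how much to the chlorine: a phenyl carrying only a chlorine and a pyridine with no chlorine would separate the two. Also open, on these data alone, is whether a methyl, a methoxy or an amine could stand in place of the chlorine on the pyridine ring and keep the number this low.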